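Chlorophenyl series: substitution on the ring nitrogen of the core

The source may hold more compounds than are shown below. What is called first, only, known or untested is meant among the compounds shown, and "the series" means these compounds.

Values in a functional assay on MCF7 cells (Homo sapiens) for inhibition, read by MTT assay, with a stated time of 5 days; on this read-out higher numbers stand for weaker inhibition and lower numbers for stronger inhibition:
compound 1 `Cc1cc(Nc2nc(NCc3ccccc3Br)nc3[nH]ncc23)n[nH]1`: 14100 nM
compound 2 `Cc1cc(Nc2nc(NCc3cccc(Cl)c3)nc3[nH]ncc23)n[nH]1`: 5620 nM
compound 3 `Cc1cc(Nc2nc(NCc3ccc(Cl)cc3)nc3[nH]ncc23)n[nH]1`: 860 nM

Compound 3 stands lowest of the three: a 16-fold lower number from compound 1 to compound 3 (1.21 log units; beyond the scatter) and a 6.5-fold lower number from compound 2 to compound 3 (0.82 log units; beyond the scatter), both beyond the scatter, so compound 3 is the most potent compound measured. Compound 4 `Cc1cc(Nc2nc(NCc3ccc(Cl)cc3)nc3c2cnn3C(C)C)n[nH]1` alters a different part of the shared core: isopropyl in place of hydrogen on an aromatic nitrogen. Within the data shown here, none of the measured steps touches this aromatic nitrogen; all three exchange the bromophenyl or chlorophenyl group on the saturated chain carbon, so they do not bear directly on the change. Among the measured compounds shown here, with no step to guide it, no change beyond the scatter is expected in this assay, and the range is kept wide. For compound 4 the estimated step is a 1.2-fold higher number from compound 3 to compound 4 (0.07 log units; within the scatter). For compound 4 the expected value is 1000 nM, within 300 nM to 4000 nM.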

Compound 4, half-maximal inhibitory concentration: 2040 nM
The estimate for compound 4 lay 2.0-fold (0.31 log units) below the measured number; the measured number falls inside the stated range.
By their numbers in this assay, from the lowest: compound 3; then compound 4; then compound 2; then compound 1.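

In this assay, among these compounds, the first step at this aromatic nitrogen, isopropyl in place of hydrogen, gives a 2.4-fold higher number from compound 3 to compound 4 (0.38 log units; beyond the scatter), so the earlier steps on the saturated chain carbon had said nothing about this position. The nitrogen accepts a carbon substituent with a modest loss of inhibition, and the hydrogen form stays the stronger of this pair. Nothing available explains this loss.

Still open, as far as these compounds go, is whether a methyl, a longer chain or a chain ending in an amine would behave the same way. Also open, from the compounds shown here alone, is whether the step holds with the 3-chlorophenyl or 2-bromophenyl groups.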